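The source may hold more compounds than are shown below. What is called first, only, known or untested is meant among the compounds shown, and "the series" means these compounds.

Measured in a functional assay on MCF7 cells (Homo sapiens) for inhibition, with a stated time of 96 h (on this read-out lower numbers stand for stronger inhibition and higher numbers for weaker inhibition), so far:
compound 1 `COc1cc(C(=O)c2cn(-c3ccc(C)cc3)cc2-c2ccoc2)cc(OC)c1OC` gives 18 nM
compound 2 `COc1cc(C(=O)c2cn(-c3ccc(C)cc3)cc2-c2nccs2)cc(OC)c1OC` gives 14 nM
compound 3 `COc1cc(C(=O)c2cn(-c3ccc(C)cc3)cc2-c2ncco2)cc(OC)c1OC` gives 42 nM

Compound 2 cannot be told apart from compound 1 (a 1.3-fold lower number from compound 1 to compound 2 (0.11 log units; within the scatter)), but it lies clear of compound 3 (a 3.0-fold higher number from compound 2 to compound 3 (0.48 log units; beyond the scatter)). Compound 4 `COc1cc(C(=O)c2cn(-c3ccc(F)cc3)cc2-c2nccs2)cc(OC)c1OC` differs from compound 2 as follows: fluoro in place of methyl on an aromatic carbon. For the measured compounds named here, no measured step touches that place. All three exchange the furan-3-yl, 1,3-thiazol-2-yl and 1,3-oxazol-2-yl groups instead, and the largest, a 3.0-fold higher number from compound 2 to compound 3 (0.48 log units; beyond the scatter), offers only a rough guide to size. The expected result is a 1.4-fold higher number from compound 2 to compound 4 (0.15 log units; within the scatter), with no shift beyond the scatter anticipated. For compound 4 the estimated value is 20 nM, with an expected range from 7 nM to 60 nM.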

Compound 4, half-maximal inhibitory concentration: 22 nM
For compound 4 the middle estimate is 1.1-fold (0.04 log units) below the measured one, and the stated range covers the measured number.
By their numbers in this assay, from the lowest: compounds 2, 1, 4 and 3 (each within the scatter of the next, the first and the last beyond it).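

In this assay, for the compounds shown here, the one step at the aromatic ring carrying the methyl group, 4-methylphenyl to 4-fluorophenyl, gives a 1.6-fold higher number from compound 2 to compound 4 (0.20 log units; within the scatter). Fluoro can therefore stand in place of methyl here without a shift that can be told from the scatter, whereas the earlier steps changed only the furan-3-yl, 1,3-thiazol-2-yl and 1,3-oxazol-2-yl groups. Nothing available explains this result.
From the compounds shown here alone, it remains open whether an amine, a carboxylic acid or a longer chain at this place would also stay within the scatter. Going by these compounds, it is equally open whether the exchange would read the same alongside furan-3-yl or 1,3-oxazol-2-yl.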